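The source may hold more compounds than are shown below. What is called first, only, known or untested is meant among the compounds shown, and "the series" means these compounds.

Measured so far:
Compound 1, `Cc1cn(C2CCN(Cc3cccc(Oc4ccc(Cl)cc4)c3)CC2)c(=O)[nH]c1=O` — 25100 nM
Compound 2, `Cc1cn(C2CCN(Cc3cccc(Oc4ccc(F)c(F)c4)c3)CC2)c(=O)[nH]c1=O` — > 64000 nM
Compound 3, `Cc1cn(C2CCN(Cc3cc(Oc4ccccc4)ccn3)CC2)c(=O)[nH]c1=O` — > 64000 nM

Going by the values given here, in an ADME assay on MRC5 cells (Homo sapiens) for cytotoxicity, read by fluorescence and resazurin assay, with a stated time of 3 days (on this read-out higher numbers stand for weaker inhibition and lower numbers for stronger inhibition), compound 1 gives 25100 nM, the only actual number among the three. Compound 2 and compound 3 each reach only a limit of the assay. For compound 2 the value > 64000 nM is such a limit. For compound 3 the value > 64000 nM is likewise a limit. Among the compounds with values here, compound 1 therefore stands as the one compound with a measured number, and the limit of > 64000 nM in this assay, at which 2 of the 3 values shown sit, is where the other two sit.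

Compound 4, `Cc1cn(C2CCN(Cc3cccc(Oc4ccc(Cl)c(C(F)(F)F)c4)c3)CC2)c(=O)[nH]c1=O`, is not yet measured. It differs from compound 1 by trifluoromethyl in place of hydrogen on an aromatic carbon.

Within the data shown here, only one measured step touches the same ring: an at least 2.5-fold higher number from compound 1 to compound 2 (0.40 log units; beyond the scatter). That step changed the halogen pattern rather than adding a group, so it bears on the new change only loosely. Among the measured compounds shown here, no measured step adds a trifluoromethyl group, so the direction for compound 4 cannot be read from the data with confidence; the one step available moved toward the limit.

The expected result for compound 4 in this assay is 28000 nM, spanning 10000 nM to 64000 nM. This estimate means a 1.1-fold higher number from compound 1 to compound 4 (0.05 log units; within the scatter), a step expected to stay within the scatter.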

Compound 4, half-maximal inhibitory concentration: 5280 nM
Compound 4: middle estimate off by 5.3-fold (0.72 log units), on the high side; the whole stated range lies above it.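

In this assay, trifluoromethyl on the aromatic carbon ortho to the chloro group gives a 4.8-fold lower number from compound 1 to compound 4 (0.68 log units; beyond the scatter), so this carbon is not a silent spot: a lower number here means stronger inhibition of the growth of these human cells, which in a cytotoxicity test is the unwanted direction. The earlier step on this ring went toward a higher number, and swapping the whole ring pattern while the rest of the molecule stays the same gives an at least 12-fold lower number from compound 2 to compound 4 (1.08 log units; beyond the scatter), so the groups on this one ring can carry the read-out across a large span. The reading for compound 2 is a limit and not a number, so the true size of that span stays unknown: the limit of > 64000 nM in this assay, at which 2 of the 4 values shown sit.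

The compounds shown do not tell whether this shift belongs to trifluoromethyl in particular, or whether a methyl group, a methoxy group or a carboxylic acid on the same carbon would do the same. They also leave open whether trifluoromethyl would give a similar step on a ring without the chloro group.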